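Swapping the aryl group on the ring nitrogen: cytotoxicity outlook

This account rests on a few compounds, and the source may have more. Where it says the series, first, only, none or still open, it means among the compounds named here.

Compound 1 `COc1ccc([C@H]2CC(=O)N(c3ccc(C)c(N)c3)C2)cc1OC1CCCC1` gives > 10000 nM in a functional assay on HEK293 cells (Homo sapiens) for cytotoxicity (a higher number here means that more compound is tolerated, a lower number that less compound is tolerated), a limit of the assay rather than a number.
Compound 2 `COc1ccc([C@H]2CC(=O)N(c3ccccc3N)C2)cc1OC1CCCC1` gives > 10000 nM in this assay, again a limit.
Compound 3 `COc1ccc([C@H]2CC(=O)N(c3cccc(C#N)c3)C2)cc1OC1CCCC1` gives > 10000 nM in this assay, also a limit.

Compound 3 therefore stands at the limit shared by all three measured compounds, as the limit of > 10000 nM in this assay, at which 3 of the 3 values shown sit, records. The steps that lead to it, a step that the two limits leave unreadable from compound 1 to compound 3 and a step that the two limits leave unreadable from compound 2 to compound 3, cannot be read in size because both ends are limits, and the same holds for a step that the two limits leave unreadable from compound 1 to compound 2.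

Compound 4 `COc1ccc([C@H]2CC(=O)N(c3ccncc3)C2)cc1OC1CCCC1` differs from compound 3 in one place: pyridin-4-yl in place of 3-cyanophenyl on an amide-type nitrogen in a ring. Within the data shown here, no measured step can be read for any change of the group on this nitrogen, so the only guide is that three different groups there all left the compound at the limit. Compound 4 is therefore expected to show no step beyond the scatter, a step that the limit leaves unreadable from compound 3 to compound 4, and is estimated at 15000 nM, between 7000 nM and 50000 nM.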

Compound 4, half-maximal cytotoxic concentration: > 10000 nM
Compound 4 was reported as a limit; the forecaster's own chance of this, stated with the estimate: 85%; the middle value is on the limit's open side.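

Compound 4 also gives a limit of the assay, so none of the steps to it from compound 1, compound 2 or compound 3 can be read in size: the limit of > 10000 nM in this assay, at which 4 of the 4 values shown sit.

The compounds shown leave open where the half-maximal cytotoxic concentration of each compound truly lies in this assay, and whether the group on the ring nitrogen affects it at all.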